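The compounds below may be only part of what the source reports. "The series", "measured", "known", "first", "only" and "open" are said of these compounds alone.

Among the compounds with values here, compound 2 `Cc1nn(-c2nc(-c3ccc(Cl)c(Cl)c3)c(SC(C)C)s2)c(C(=O)O)c1-c1cccc(F)c1` gives in a functional assay on BJAB cells (Homo sapiens) for antiproliferative activity, with a stated time of 4 days (on this read-out higher numbers stand for an effect only at larger amounts of compound and lower numbers for an effect already at smaller amounts), a value of 900 nM, the only number recorded for any compound here. Compound 1 `Cc1c(-c2cc(Cl)cc(Cl)c2)c(C(=O)O)nn1-c1nc(-c2cccnc2)c(SC(C)C)s1` was reported in this assay without a number, as "not active" (no number reported). Compound 1 and compound 2 differ in more than one place, so no single step can be read between them. Compound 3 `Cc1cc(Cl)cc(-c2c(C)nn(-c3nc(-c4ccc(Cl)c(Cl)c4)c(SC(C)C)s3)c2C(=O)O)c1` differs from compound 2 in one place: 3-chloro-5-methylphenyl in place of 3-fluorophenyl on an aromatic carbon. Within the data shown here, no measured pair shows the effect of such a change, so nothing in the data fixes the size of the move from compound 2 to compound 3 in this assay. The expectation is a change that stays near the usual scatter, with a slight lean toward an effect only at larger amounts, which is an estimated step of a 1.4-fold higher number from compound 2 to compound 3 (0.16 log units; within the scatter). Compound 3 is expected to give about 1300 nM in this assay, with a likely range from 400 nM to 4500 nM.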

Compound 3, half-maximal effective concentration: 663 nM
For compound 3 the middle estimate is 2.0-fold (0.29 log units) above the measured one; low and high end bracket the measured number.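

In this assay, putting 3-chloro-5-methylphenyl in place of 3-fluorophenyl gives a 1.4-fold lower number from compound 2 to compound 3 (0.13 log units; within the scatter), so the two compounds cannot be told apart. Within the data shown here, this is the first step that can be read at this aromatic carbon of the five-membered ring, and it shows that a phenyl ring carrying chlorine and methyl can stand here in place of one carrying fluorine with no change beyond the usual scatter. Nothing available explains why the two compounds read alike.

This single step cannot separate the part played by the chlorine from that of the methyl, since neither 3-chlorophenyl nor 3-methylphenyl is among the compounds shown. It also leaves open how the assay would respond to something other than a substituted phenyl ring at this carbon, such as an amine or a longer carbon chain.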